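The compounds below may be only part of what the source reports. "The series", "measured", "known", "first", "only" and "open" are said of these compounds alone.

Of the compounds shown here, three built on a shared core have been measured in an assay on Sf9 cells for inhibition of serine/threonine-protein kinase 4 (Homo sapiens), read by luminescence and ADP-Glo, with a stated time of 1 h, in the presence of a further agent that is not named here; a higher number here means a weaker inhibitor, a lower number a stronger inhibitor. Compound 1 `CN1C(=O)C(C2CC2)N(C)c2nc(Nc3ccc(S(N)(=O)=O)cc3)ncc21` gives 136 nM. Compound 2 `CC(C)CC1C(=O)N(C)c2cnc(Nc3ccc(S(N)(=O)=O)cc3)nc2N1C` gives 77 nM. Compound 3 `Cc1ccc(F)cc1C1C(=O)N(C)c2cnc(Nc3ccc(S(N)(=O)=O)cc3)nc2N1C` gives 168 nM, which is the highest of the three numbers, though its distance from compound 1 is small: a 1.2-fold higher number from compound 1 to compound 3 (0.09 log units; within the scatter). Its distance from compound 2 is a little larger, as a 2.2-fold higher number from compound 2 to compound 3 (0.34 log units; beyond the scatter).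

Compound 4 `CN1C(=O)C(c2cccs2)N(C)c2nc(Nc3ccc(S(N)(=O)=O)cc3)ncc21` has not yet been measured. The change from compound 3 is thiophen-2-yl in place of 5-fluoro-2-methylphenyl on a saturated ring carbon. The two steps that bear on this position are those just named: the exchange of cyclopropyl for 5-fluoro-2-methylphenyl stayed within the scatter, and the exchange of isobutyl for 5-fluoro-2-methylphenyl gave only a modest rise. Three quite different groups on this saturated ring carbon have thus all landed within a narrow span, which gives no ground to expect a large move from a fourth. The thiophen-2-yl group is therefore expected to produce a step no larger than a 1.4-fold lower number from compound 3 to compound 4 (0.15 log units; within the scatter) in this assay, if any beyond the scatter. Compound 4 is estimated at 120 nM, with a likely range from 50 nM to 320 nM.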

Compound 4, half-maximal inhibitory concentration: 88 nM
Estimate against measurement, compound 4: 1.4-fold (0.13 log units) above; low and high end bracket the measured number.
By their numbers in this assay, from the lowest: compounds 2, 4, 1 and 3 (each within the scatter of the next, the first and the last beyond it).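

In this assay the thiophen-2-yl group places a five-membered aromatic ring with a hetero atom, and a hydrogen-bond acceptor, on this saturated ring carbon, yet all three of its steps stay within the scatter: a 1.9-fold lower number from compound 3 to compound 4 (0.28 log units; within the scatter), a 1.1-fold higher number from compound 2 to compound 4 (0.06 log units; within the scatter) and a 1.5-fold lower number from compound 1 to compound 4 (0.19 log units; within the scatter). Compound 2 and compound 3 stand beyond the scatter of each other, while compound 4 cannot be told from either, so an aromatic ring on this carbon is not by itself shown to separate a compound from the isobutyl compound 2. Nothing available here gives a reason for the size of these steps.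

Going by these compounds, all four groups at this position are uncharged carbon-based groups, so it remains open whether an amine or a carboxylic acid on this saturated ring carbon, or a plain hydrogen there, would stay within the same narrow span. The compounds shown also leave open how a pyridine ring or a longer chain would behave here, and whether the same span would hold with the sulfonamide replaced by another group.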